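Working notes: compound 3 to compound 4, shared core series

The source may report more compounds than this note shows. Statements on the series, on what has been measured and on what is new or still open speak of the compounds shown alone.

Three compounds of the series have numbers in a functional assay on cells for antagonist activity at C-X-C chemokine receptor type 4 (Homo sapiens), read by fluorescence and calcium flux, with stated times of 25 min and 90 s; on this read-out higher numbers stand for weaker inhibition and lower numbers for stronger inhibition. Compound 1 `c1ccc(CN(CCCCN(C[C@H]2Cc3ccccc3CN2)[C@H]2CCCc3cccnc32)Cc2ccccn2)nc1` gives 664 nM in this assay, and compound 2 `c1ccc2c(c1)CN[C@@H](CN(CCCCN(Cc1ccncc1)Cc1ccncc1)[C@H]1CCCc3cccnc31)C2` gives 832 nM. Compound 3 `c1ccc2c(c1)CN[C@@H](CN(CCCCNCC1CCNCC1)[C@H]1CCCc3cccnc31)C2` gives 36.5 nM and thus stands lowest of the three; its gaps to compound 1 and to compound 2 both lie beyond the scatter, so compound 3 is the strongest inhibitor among the measured members.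

Compound 4 `CC1(C)CCC(NCCCCN(C[C@H]2Cc3ccccc3CN2)[C@H]2CCCc3cccnc32)CC1` is not yet measured. It differs from compound 3 in one place: 4,4-dimethylcyclohexyl in place of (piperidin-4-yl)methyl on an amine nitrogen. Among the measured compounds shown here, no pair of measured compounds differing in a single place is available, so there is no measured step to lean on for this kind of change; the three numbers only show how far compound 3 sits from compound 1 and compound 2.

For compound 4 the expectation is a step upward, that is toward weaker inhibition, of a size clearly beyond the scatter, written as an 8.2-fold higher number from compound 3 to compound 4 (0.91 log units; beyond the scatter). For the measured compounds named here, the estimated value for compound 4 in this assay is 300 nM, with an expected range from 60 nM to 1500 nM, the wide range reflecting that no measured example of this change exists.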

Compound 4, half-maximal inhibitory concentration: 77.6 nM
Compound 4: the middle estimate sits 3.9-fold (0.59 log units) above what was measured, within the range that was stated.
By their numbers in this assay, from the lowest: compound 3; then compound 4; then compounds 1 and 2 (each within the scatter of the next).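

Among the compounds shown here, this is the first step that changes a single place: on the amine nitrogen, 4,4-dimethylcyclohexyl in place of (piperidin-4-yl)methyl gives a 2.1-fold higher number from compound 3 to compound 4 (0.33 log units; beyond the scatter) in this assay, a modest rise just past the usual scatter. The entering group is carbon only, with 0 hydrogen-bond donors and 0 hydrogen-bond acceptors against 1 of each in the leaving group, yet compound 4 still gives 77.6 nM, so at this position a ring nitrogen is not needed for a value of this order, at least in this one pair. Nothing measured here speaks to why the step has this size.

For the compounds shown here, the change alters several features at once, so the single pair cannot apportion the step among the loss of the ring nitrogen, the two methyl groups and the loss of the methylene link to the amine nitrogen. A plain cyclohexyl, a cyclohexylmethyl or a piperidin-4-yl on the same amine nitrogen would split the change into separate parts, and each would show which part carries the step.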